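A few compounds are considered here, and "the series" means these few. Any claim that something is new, unique, unknown or untested is made for them only; others in the source may bear on it.

Compound 1, `CCCCCc1cc(-c2cn([C@H]3C[C@H](OC(C)=O)[C@@H](COC(C)=O)O3)c(=O)[nH]c2=O)on1`: 99.8%
Compound 2, `CC(=O)OC[C@H]1O[C@@H](n2cc(-c3cn(Cc4ccccc4)nn3)c(=O)[nH]c2=O)C[C@@H]1OC(C)=O`: 99%
Compound 3, `CCCCCCCCc1cc(-c2cn([C@H]3C[C@H](O)[C@@H](CO)O3)c(=O)[nH]c2=O)on1`: 95.6%

All three were read in a functional assay on ACHN cells (Homo sapiens) for cytotoxicity, read by sulforhodamine B assay, tested at 10 uM; a higher number here means more inhibition at the concentration tested (going by the name of the read-out), a lower number less inhibition. Compound 1 gives the highest of the three numbers, yet compound 2 and compound 3 both lie within the usual scatter of it, so no order among them can be drawn. Compound 4, `CCCCc1ccc(-c2cc(-c3cn([C@H]4C[C@H](OC(C)=O)[C@@H](COC(C)=O)O4)c(=O)[nH]c3=O)on2)cc1`, has not yet been measured. It differs from compound 1 in one place: 4-butylphenyl in place of pentyl on an aromatic carbon. Because compound 1 already sits near the top of the scale at 99.8%, little room is left for any rise. For compound 4 the expected step is a number 3.8 percentage points lower from compound 1 to compound 4 (within the scatter), which is none beyond the scatter. Compound 4 is therefore estimated to give 96% in this assay, with a range from 84% to 100%.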

Compound 4, a percentage reported as inhibition, at one concentration (the size of the read-out at that concentration, not a potency): 80.5%
Compound 4: the middle estimate sits 15.5 percentage points above what was measured; the measured number lies below the stated range.
By their numbers in this assay, from the lowest: compound 4; then compounds 3, 2 and 1 (each within the scatter of the next).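

Within the data shown here, putting 4-butylphenyl in place of pentyl on this aromatic carbon gives a number 19.3 percentage points lower from compound 1 to compound 4 (beyond the scatter) in this assay and so shows that the read-out depends on what this position carries, which no earlier pair of compounds could show. The step is modest and rests on this single pair. Nothing measured here explains it.

From the compounds shown here alone, whether the six-membered aromatic ring or simply the larger group matters remains open. A plain phenyl without the butyl chain or a longer alkyl chain at this position would help separate the two.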